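Carbonate chain length in a shared-core series

A few compounds are considered here, and "the series" means these few. Any claim that something is new, unique, unknown or untested is made for them only; others in the source may bear on it.

Measured so far in an ADME assay for pharmacokinetics, read by HPLC, at 37 degrees C, at pH 1.2; a higher number here means that the compound lasts longer, a lower number that the compound disappears faster:
compound 1 `CCOC(=O)OCC(CO)CCn1cnc2cnc(N)nc21`: 840 h
compound 2 `CCCCCOC(=O)OCC(CO)CCn1cnc2cnc(N)nc21`: 600 h
compound 3 `CC(C)COC(=O)OCC(CO)CCn1cnc2cnc(N)nc21`: 672 h

Compound 3 stands second highest of the three numbers in this assay; its nearest neighbour is compound 2 and its furthest is compound 1, and both gaps are within the scatter, so the three compounds cannot be ordered on these data.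

Next is compound 4 `CC(C)CCOC(=O)OCC(CO)CCn1cnc2cnc(N)nc21`. The change from compound 3 is isobutyl in place of isopropyl on a saturated chain carbon bound to an oxygen next to a carbonyl group.

Two measured steps vary the same position on a saturated chain carbon bound to an oxygen next to a carbonyl group: a 1.3-fold lower number from compound 1 to compound 3 (0.10 log units; within the scatter) and a 1.1-fold higher number from compound 2 to compound 3 (0.05 log units; within the scatter). The third step, a 1.4-fold lower number from compound 1 to compound 2 (0.15 log units; within the scatter), also stays within the scatter. Every change of the carbonate alkyl group seen so far, whether longer or branched, has left this assay unchanged beyond the scatter, so no step beyond the scatter is expected in either direction; the expected step is a 1.0-fold lower number from compound 3 to compound 4 (0.01 log units; within the scatter).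

Compound 4 is therefore estimated at 650 h in this assay, with a range from 420 h to 1000 h.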

Compound 4, half-life in the ADME assay: 576 h
Compound 4: middle estimate off by 1.1-fold (0.05 log units), on the high side; the range from low to high includes it.
By their numbers in the ADME assay, from the lowest: compounds 4, 2, 3 and 1 (each within the scatter of the next).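

In the ADME assay the isopentyl carbonate stays within the scatter of all three earlier compounds: a 1.2-fold lower number from compound 3 to compound 4 (0.07 log units; within the scatter), a 1.0-fold lower number from compound 2 to compound 4 (0.02 log units; within the scatter) and a 1.5-fold lower number from compound 1 to compound 4 (0.16 log units; within the scatter). Across the four compounds, then, the half-life does not resolve any of these alkyl groups from the others, and isobutyl in place of isopropyl adds nothing new in that read-out. The same change does separate a pair in a physicochemical assay for solubility, read by spectrophotometry, at 20 degrees C (a higher number here means a more soluble compound, a lower number a less soluble compound), where compound 3 gives 1500 ug/mL and compound 4 gives 5600 ug/mL, the first step at this position beyond the scatter: the measured solubility of compound 3, 1500 ug/mL, and of compound 4, 5600 ug/mL, a 3.7-fold higher number (0.57 log units; beyond the scatter)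

A single pair carries the solubility comparison, so no trend with chain length or branching can be drawn from it. Going by these compounds, whether an amine, a carboxylic acid or a longer chain at this position would move the half-life beyond the scatter remains open.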